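The compounds below may be only part of what the source reports. "The series", "measured", "known", "first", "only" and "open" are said of these compounds alone.

Measured so far:
compound 1, `CC(C)=CCOc1c(C)c(C)c2c(c1C)CCC(C)(COc1ccc(/C=C3\SC(=O)NC3=O)cc1-c1ccc(F)cc1)O2`, in a functional assay on MCF7 cells (Homo sapiens), tested at 5 uM; a higher number here means a weaker effect of the compound at the concentration tested, a lower number a stronger effect: 92%
compound 2, `Cc1c(C)c2c(c(C)c1OCc1ccccc1)CCC(C)(COc1ccc(/C=C3\SC(=O)NC3=O)cc1)O2`: 42%

Compound 2 stands lowest of the two numbers in this assay, and compound 1 is the nearer and only neighbour, its number higher by a gap beyond the usual scatter. Going by the values given here, no step between these two is computed here, since they differ in more than one place, so only the two values themselves are known.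

The piece follows one change from compound 2 to compound 3, `C=CCOc1c(C)c(C)c2c(c1C)CCC(C)(COc1ccc(/C=C3\SC(=O)NC3=O)cc1)O2`, which has not yet been measured in this assay. The change is vinyl in place of phenyl on a saturated chain carbon bound to an oxygen on an aromatic ring. Read one bond further out, benzyl gives way to allyl, so the group on the oxygen of the aromatic ring shrinks from a six-membered aromatic ring of carbon only to a short chain with one double bond.

Among the compounds with values here, no step between measured compounds is known. Compound 3 is estimated to give 55% in this assay, with a range from 35% to 80%. That estimate means a step of a number 13 percentage points higher from compound 2 to compound 3 (beyond the scatter), a modest weakening that could still fall within the scatter.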

Compound 3, a percentage reported as activity, at one concentration (the size of the read-out at that concentration, not a potency): 42%
For compound 3 the middle estimate is 13 percentage points above the measured one; the range from low to high includes it.
By their numbers in this assay, from the lowest: compounds 2 and 3 (each within the scatter of the next); then compound 1.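

In this assay, the exchange of phenyl for vinyl on a saturated chain carbon bound to an oxygen on an aromatic ring, which reads one bond further out as benzyl to allyl, comes out as no change at the digits printed from compound 2 to compound 3 (within the scatter). At this position, then, the six-membered aromatic ring of carbon only is not needed to keep the read-out at the concentration tested, since a short chain with one double bond serves equally well in this pair. Nothing available explains why the two groups stand level, so the result remains an observation about this one pair.

The compounds shown leave open how far this tolerance extends, for instance whether a longer saturated chain, an amine or a carboxylic acid on the same oxygen would keep the number of compound 3 or move it beyond the scatter. Steps to compound 1 cannot be read, as it differs from both other compounds in more than one place, so its higher number cannot be assigned to any single group.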